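A trifluoromethyl swap at the assay limit

This account rests on a few compounds, and the source may have more. Where it says the series, first, only, none or still open, it means among the compounds named here.

Compound 1 (`Cc1cc(=O)c(O)c(Cc2ccccc2)o1`) and two halogenated relatives share one core. In a functional assay on U-87MG ATCC cells for antiproliferative activity against U-87 MG (Homo sapiens), read by MTT assay (on this read-out higher numbers stand for weaker inhibition and lower numbers for stronger inhibition), compound 1 gives > 50000 nM as a limit, not a number. Compound 2 (`Cc1cc(=O)c(O)c(Cc2ccc(F)cc2)o1`) gives > 50000 nM as a limit too. Compound 3 (`Cc1cc(=O)c(O)c(Cc2ccc(Cl)cc2)o1`) gives > 50000 nM as a limit as well. Among the compounds with values here, the only firm mark for compound 3 is the limit of > 50000 nM in this assay, at which 3 of the 3 values shown sit, and nothing finer.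

Compound 4 (`Cc1cc(=O)c(O)c(Cc2ccc(C(F)(F)F)cc2)o1`) has trifluoromethyl in place of chloro (trifluoromethyl in place of chloro on an aromatic carbon) on an aromatic carbon, para to a large group. Within the data shown here, three measured steps bear on this change: a step that the two limits leave unreadable from compound 1 to compound 2 and a step that the two limits leave unreadable from compound 1 to compound 3 and a step that the two limits leave unreadable from compound 2 to compound 3 give no size to build on. Neither halogen moved compound 2 or compound 3 off the limit, so no step beyond the scatter is expected in this assay in either direction. The estimated change is a number no higher from compound 3 to compound 4 (the limit leaves the size open) and remains a rough expectation. For compound 4 the expected value is 50000 nM with an estimated range of 25000 nM to 100000 nM around it.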

Compound 4, half-maximal inhibitory concentration: > 50000 nM
Compound 4 gave a limit, no number; the forecaster's own chance of this, stated with the estimate: 85%; the middle value lies on the limit itself.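

Compound 4, like compound 1, compound 2 and compound 3, gives only a limit, so no step among these four compounds can be read: the limit of > 50000 nM in this assay, at which 4 of the 4 values shown sit.

The compounds shown leave open whether hydrogen, fluoro, chloro or trifluoromethyl at this place makes any difference in this assay.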